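Topoisomerase 1 inhibition: phenol versus aniline on the shared core

The source may report more compounds than this note shows. Statements on the series, on what has been measured and on what is new or still open speak of the compounds shown alone.

Compound 1: `COc1ccc(-c2cc3ccccc3c(-c3cccc(O)c3)n2)cc1`, 9.4%
Compound 2: `COc1ccc(-c2cc3ccccc3c(-c3cccc(OC)c3)n2)cc1`, 43.2%
Compound 3: `COc1ccc(-c2cc3ccccc3c(-c3cccc(N)c3)n2)cc1`, 0%

All three were tested in an assay on isolated protein for inhibition of DNA topoisomerase 1 (Homo sapiens), with a stated time of 30 min, tested at 100 uM; a higher number here means a stronger effect of the compound at the concentration tested, a lower number a weaker effect. Compound 3 has the lowest of the three numbers. The step of a number 9.4 percentage points lower from compound 1 to compound 3 (within the scatter) stays within the scatter, so compound 1 and compound 3 cannot be ordered, whereas the step of a number 43.2 percentage points lower from compound 2 to compound 3 (beyond the scatter) is large. The step of a number 33.8 percentage points higher from compound 1 to compound 2 (beyond the scatter) is likewise large.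

Compound 4, `COc1ccc(-c2cc3ccccc3c(-c3ccc(O)cc3)n2)cc1`, is not yet measured in this assay . Relative to compound 3 the change is 4-hydroxyphenyl in place of 3-aminophenyl on an aromatic carbon. Among the compounds with values here, the only measured step that bears on it is a number 9.4 percentage points lower from compound 1 to compound 3 (within the scatter), which exchanges amino for hydroxy on the same aromatic carbon and stayed within the scatter. Within the data shown here, no measured step compares a 3-aminophenyl group with a 4-hydroxyphenyl group, so the shift of the donor within the phenyl ring has no precedent here. The step of a number 10 percentage points higher from compound 3 to compound 4 (within the scatter) is therefore the expected one, small and upward if at all. Compound 4 is estimated at 10%, with a range of 0% to 30%.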

Compound 4, a percentage reported as inhibition, at one concentration (the size of the read-out at that concentration, not a potency): 6.7%
For compound 4 the middle estimate is 3.3 percentage points above the measured one, within the range that was stated.
By their numbers in this assay, from the lowest: compounds 3, 4 and 1 (each within the scatter of the next); then compound 2.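

Moving the hydroxy group, with 4-hydroxyphenyl in place of 3-hydroxyphenyl, gives the step of a number 2.7 percentage points lower from compound 1 to compound 4 (within the scatter) in this assay, so its placement on this ring has no readable effect here, and the step of a number 6.7 percentage points higher from compound 3 to compound 4 (within the scatter) likewise leaves compound 3 and compound 4 unordered. The large step of a number 36.5 percentage points lower from compound 2 to compound 4 (beyond the scatter) leaves compound 2, with its 3-methoxyphenyl group, clearly apart from all three compounds carrying a hydroxy or amino group. Nothing available explains this separation.

The compounds shown leave open whether 4-methoxyphenyl on this aromatic carbon would stay near compound 2 or fall among the others. Also open, from the compounds shown here alone, is how a longer chain on the oxygen, such as ethoxy, or a carboxylic acid at this ring would read in this assay.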